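The source may report more compounds than this note shows. Statements on the series, on what has been measured and on what is new or still open speak of the compounds shown alone.

Compound 1 `CCN(CC)S(=O)(=O)NC(=O)Nc1c(C(C)C)cccc1C(C)C` carries a diethylamino group on the sulfonyl sulfur of a shared core. In an assay on liver for inhibition of sterol O-acyltransferase 1 (Rattus norvegicus), using microsomes (on this read-out higher numbers stand for weaker inhibition and lower numbers for stronger inhibition), compound 1 gives 2500 nM, the lowest of the three numbers recorded. Compound 3 `C=CCN(CC=C)S(=O)(=O)NC(=O)Nc1c(C(C)C)cccc1C(C)C`, with a diallylamino group in that place, gives 2700 nM in this assay, and the step of a 1.1-fold higher number from compound 1 to compound 3 (0.03 log units; within the scatter) lies within the scatter. Compound 2 `CC(C)c1cccc(C(C)C)c1NC(=O)NS(=O)(=O)N1CCCC1`, with a pyrrolidin-1-yl group in that place, gives 15000 nM in this assay; the steps of a 6.0-fold higher number from compound 1 to compound 2 (0.78 log units; beyond the scatter) and a 5.6-fold lower number from compound 2 to compound 3 (0.74 log units; beyond the scatter) show that pyrrolidin-1-yl in place of either open-chain amino group weakened inhibition by a modest but clear amount.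

Compound 4 `CC(C)c1cccc(C(C)C)c1NC(=O)NS(=O)(=O)N1CCCCC1` is the unmeasured member of the set. Its difference from compound 1 is piperidin-1-yl in place of diethylamino on a sulfonyl sulfur. Within the data shown here, the only measured change of the same kind is the one from compound 1 to compound 2, where a ring-closed amino group replaced the diethylamino group and the number rose. Among the measured compounds shown here, a six-membered ring has no measured precedent here, so the expected step for compound 4 in this assay is a 2.4-fold higher number from compound 1 to compound 4 (0.38 log units; beyond the scatter), an upward move of moderate size. Compound 4 is therefore estimated at 6000 nM in this assay, within a range from 2000 nM to 20000 nM.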

Compound 4, half-maximal inhibitory concentration: 17000 nM
The estimate for compound 4 lay 2.8-fold (0.45 log units) below the measured number, within the range that was stated.
By their numbers in this assay, from the lowest: compounds 1 and 3 (each within the scatter of the next); then compounds 2 and 4 (each within the scatter of the next).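

On the sulfonyl sulfur, the piperidin-1-yl group cannot be told apart from the pyrrolidin-1-yl group in this assay (a 1.1-fold higher number from compound 2 to compound 4 (0.05 log units; within the scatter)), so the larger ring brings no recovery in inhibition. Set against the two open-chain groups, piperidin-1-yl gives clear rises in the number (a 6.8-fold higher number from compound 1 to compound 4 (0.83 log units; beyond the scatter); a 6.3-fold higher number from compound 3 to compound 4 (0.80 log units; beyond the scatter)), and these are similar in size to the rises seen earlier with pyrrolidin-1-yl. The loss of inhibition therefore no longer rests on a single ring: these four compounds form two pairs, with the open-chain compounds 1 and 3 at the lower numbers and the ring-bearing compounds 2 and 4 at the higher numbers, and none of the four goes against this split.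

Going by these compounds, it remains open whether a morpholin-4-yl ring, which carries an oxygen atom, or a shorter open-chain group such as dimethylamino would fall with the ring pair or with the open-chain pair. Nothing offered alongside these numbers accounts for the split between the two pairs.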